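Extending the amine side chain of compound 2

A few compounds are considered here, and "the series" means these few. Any claim that something is new, unique, unknown or untested is made for them only; others in the source may bear on it.

Of the compounds shown here, two have been measured in a functional assay on HCT-15 cells (Homo sapiens) for inhibition, read by MTT assay, with a stated time of 72 h; on this read-out lower numbers stand for stronger inhibition and higher numbers for weaker inhibition. Compound 1 `COc1cc(Oc2cccc(Nc3ccccc3)c2)cc(OC)c1CNCc1ccccc1` gives 5020 nM, and compound 2 `CNCc1c(OC)cc(Oc2cccc(Nc3ccccc3)c2)cc1OC` gives 8930 nM. Compound 2 has the higher of the two numbers, but the step of a 1.8-fold higher number from compound 1 to compound 2 (0.25 log units; within the scatter) stays within the scatter, so the two cannot be told apart. Compound 3 `COc1cc(Oc2cccc(Nc3ccccc3)c2)cc(OC)c1CNCCNC(C)=O` is compound 2 with acetamidomethyl in place of hydrogen on a saturated chain carbon bound to an amine nitrogen. Among the compounds with values here, the only measured step, from compound 1 to compound 2, also changed the group on that same chain carbon, and it did not move the number beyond the scatter. On that basis the change to compound 3 is expected to leave this assay essentially unchanged, with no step beyond the scatter in either direction, an estimated 1.3-fold lower number from compound 2 to compound 3 (0.11 log units; within the scatter). Compound 3 is therefore expected to give about 7000 nM, with a range from 2500 nM to 20000 nM.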

Compound 3, half-maximal inhibitory concentration: 5090 nM
Compound 3: the middle estimate sits 1.4-fold (0.14 log units) above what was measured, and the stated range covers the measured number.
By their numbers in this assay, from the lowest: compounds 1, 3 and 2 (each within the scatter of the next).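

In this assay, acetamidomethyl on this saturated chain carbon bound to an amine nitrogen brings in a hydrogen-bond donor and a hydrogen-bond acceptor, yet the number stays within the scatter both for a 1.8-fold lower number from compound 2 to compound 3 (0.24 log units; within the scatter) and for a 1.0-fold higher number from compound 1 to compound 3 (0.01 log units; within the scatter) in this comparison. Hydrogen, phenyl and acetamidomethyl at this position therefore give numbers that cannot be told apart, so three groups of very different size and make-up have so far left this read-out without a step beyond the scatter. Nothing measured here offers an explanation for this flat result.

From the compounds shown here alone, whether any group at this position can move the number beyond the scatter stays open. A carboxylic acid, a free amine at the end of the chain or a longer chain could each test this.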